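Methyl position on the pyridine of compound 1

The source may hold more compounds than are shown below. What is called first, only, known or untested is meant among the compounds shown, and "the series" means these compounds.

Compound 1 `Cc1ccnc([C@@H](C)Oc2cc3oc(=O)n(CCC(=O)O)c3cc2Cl)c1` gives 2.15 in a physicochemical assay for lipophilicity, read by HPLC, at pH 7.4 (on this read-out higher numbers stand for higher lipophilicity and lower numbers for lower lipophilicity), the highest of the three numbers shown, with compound 3 `O=C(O)CCn1c(=O)oc2cc(OCC3CC3)c(Cl)cc21` at 2.09 and compound 2 `CCc1cc2oc(=O)n(CCC(=O)O)c2cc1Cl` at 1.94 both within the scatter of it. Among the compounds with values here, the only step between measured compounds, a number 0.15 log units higher from compound 2 to compound 3 (within the scatter), concerns another part of the shared core and does not bear on the change considered here. Compound 4 `Cc1ccc([C@@H](C)Oc2cc3oc(=O)n(CCC(=O)O)c3cc2Cl)nc1` differs from compound 1 by 5-methylpyridin-2-yl in place of 4-methylpyridin-2-yl on a saturated chain carbon bound to an oxygen on an aromatic ring and a saturated chain carbon, the same atoms joined differently. Within the data shown here, no measured pair shows such a change, so nothing beyond the scatter is expected in this assay. The estimate for compound 4 is 2.15, with a range from 1.85 to 2.45. This corresponds to an expected step of no change at the digits printed from compound 1 to compound 4 (within the scatter).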

Compound 4, distribution coefficient: 2.02
For compound 4 the middle estimate is 0.13 log units above the measured one, within the range that was stated.
By their numbers in this assay, from the lowest: compounds 2, 4, 3 and 1 (each within the scatter of the next).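

In this assay, within the data shown here, 5-methylpyridin-2-yl in place of 4-methylpyridin-2-yl on the saturated chain carbon gives a number 0.13 log units lower from compound 1 to compound 4 (within the scatter) and is the first step to touch this position. The read-out therefore does not separate the two methyl placements. No measurement at hand offers an explanation for this step.

As far as these compounds go, whether a methoxy group or a trifluoromethyl group in place of the methyl on the pyridine would move the number beyond the scatter remains open. Also open, from the compounds shown here alone, is whether the two methyl placements stay this close in any read-out other than lipophilicity.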